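The source may hold more compounds than are shown below. What is called first, only, known or untested is meant among the compounds shown, and "the series" means these compounds.

Working notes on the series.

The shared core is carried by compound 1 `FC(F)(F)c1ccc2[nH]c(-c3ccccc3)nc2c1`, which in a functional assay on aorta (Rattus norvegicus, strain Wistar) for inhibition, with a stated time of 60 min (a lower number here means that less compound is needed, a higher number that more compound is needed for the effect), gives 468000 nM, the highest number among the three compounds measured. Compound 2 `Oc1ccc(-c2nc3cc(C(F)(F)F)ccc3[nH]2)cc1` gives 219000 nM in this assay, and compound 3 `O=[N+]([O-])c1ccccc1-c1nc2cc(C(F)(F)F)ccc2[nH]1` gives 15000 nM.

The step to compound 4 `COc1ccccc1-c1nc2cc(C(F)(F)F)ccc2[nH]1` is methoxy in place of hydrogen on an aromatic carbon. Going by the values given here, two measured steps bear on it. The step of a 2.1-fold lower number from compound 1 to compound 2 (0.33 log units; beyond the scatter) shows that a single added oxygen-bearing group on the same phenyl ring moves the number only a little. The step of a 31-fold lower number from compound 1 to compound 3 (1.49 log units; beyond the scatter) shows that a group without a hydrogen-bond donor can move the number far more. Among the compounds with values here, the methoxy group, like the nitro group, carries no hydrogen-bond donor, but no measured compound carries exactly this group, so the size of its step is uncertain. A moderate step down is expected, smaller than that seen with compound 3 and nearer that of compound 2.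

Compound 4 is therefore estimated at 100000 nM, with a range of 30000 nM to 300000 nM, corresponding to an expected step of a 4.7-fold lower number from compound 1 to compound 4 (0.67 log units; beyond the scatter).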

Compound 4, half-maximal effective concentration: 575000 nM
The estimate for compound 4 lay 5.8-fold (0.76 log units) below the measured number; measured number above the stated range.
By their numbers in this assay, from the lowest: compound 3; then compound 2; then compounds 1 and 4 (each within the scatter of the next).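

In this assay, methoxy in place of hydrogen, ortho to a large group, gives no step beyond the scatter: a 1.2-fold higher number from compound 1 to compound 4 (0.09 log units; within the scatter). At this same place the identity of the group matters greatly, as methoxy in place of nitro gives a 38-fold higher number from compound 3 to compound 4 (1.58 log units; beyond the scatter), so having 0 hydrogen-bond donors does not by itself go with a low number in this pair of compounds. No measurement shown accounts for the gap between the nitro and methoxy compounds.

The compounds shown leave open whether an amine or a nitrile at this place would track nitro or methoxy. They also leave open whether nitro keeps its large step when placed elsewhere on the phenyl ring, and how hydroxy behaves at this place.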